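From pyridin-3-yl to phenyl in a half-life series

The source may hold more compounds than are shown below. What is called first, only, known or untested is meant among the compounds shown, and "the series" means these compounds.

Measured so far in an ADME assay (liver) for metabolic stability, with Liver microsome (Homo sapiens) as the target, read by LC-MS, using microsomes, tested at 1 uM; on this read-out higher numbers stand for a longer-lived compound and lower numbers for a shorter-lived compound:
- compound 1 `CCN(CC)CCCN/C(=N\c1ccnc2cc(Cl)ccc12)c1cccnc1` gives 0.6 h
- compound 2 `C/C(=N/c1ccnc2cc(Cl)ccc12)NC1CCN(Cc2ccccc2)CC1` gives > 1 h as a limit
- compound 3 `CCN(CC)CCN/C(C)=N\c1ccnc2cc(Cl)ccc12` gives 0.433 h

Compound 1 at 0.6 h and compound 3 at 0.433 h lie within the usual scatter of each other. Compound 2 stands at > 1 h and this is a limit, not a number.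

Compound 4 `CCN(CC)CCCN/C(=N\c1ccnc2cc(Cl)ccc12)c1ccccc1` carries phenyl in place of pyridin-3-yl on a carbon with a double bond to nitrogen and is otherwise the same as compound 1. For the measured compounds named here, no measured pair shows this change. In this assay the expected step of a 1.2-fold lower number from compound 1 to compound 4 (0.08 log units; within the scatter) is estimated to stay within the scatter, with no firm direction. For compound 4 the estimate is 0.5 h with an expected range from 0.22 h to 1.1 h on this read-out.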

Compound 4, half-life: 0.35 h
Beside the measured number, compound 4's estimate is 1.4-fold (0.15 log units) above it; low and high end bracket the measured number.
By their numbers in this assay, from the lowest: compounds 4, 3 and 1 (each within the scatter of the next). At a limit, above all of these: compound 2.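

For the compounds shown here, this gives the first step that changes one place only: in this assay, the change on a carbon with a double bond to nitrogen gives a 1.7-fold lower number from compound 1 to compound 4 (0.23 log units; within the scatter). Replacing pyridin-3-yl with phenyl therefore does not separate the two compounds on this read-out, and no direction can be assigned to the change. Nothing in the data on hand gives a cause for this step.

As far as these compounds go, whether pyridin-4-yl or a carboxylic acid at this place would move the half-life beyond the scatter remains open. So does whether the same change would read alike with a shorter amine chain.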